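The compounds below may be only part of what the source reports. "The series", "measured", "known", "first", "only" and "open" are said of these compounds alone.

In a functional assay on MCF7 cells (Homo sapiens) for cytotoxicity, read by MTT assay, with a stated time of 72 h (on this read-out higher numbers stand for weaker inhibition and lower numbers for stronger inhibition), compound 1 `COc1ccc(/C(=C(/CCCl)c2ccccc2)c2ccccc2)cc1` gives > 50000 nM, which is a limit of the assay and not a number. For the measured compounds named here, compound 2 `COc1ccc(/C(=C(/CCNC(=O)NC2CCCCC2)c2ccccc2)c2ccccc2)cc1` gives 37200 nM, the only true number so far, so there is no series yet against which to rank it. Compound 3 `COc1ccc(/C(=C(/CCNC(=O)C(=O)NCc2ccccc2)c2ccccc2)c2ccccc2)cc1` keeps the shared core and the chain of compound 2, and the change lies at the far end of that chain: benzylcarbamoyl in place of cyclohexylamino on a carbonyl carbon. Going by the values given here, only one measured step can guide expectations here, and it involves different groups. This step, an at least 1.3-fold lower number from compound 1 to compound 2 (0.12 log units; that floor lies within the scatter), replaced chloro with (cyclohexylcarbamoyl)amino on the chain, and it offers no firm evidence of a change in either direction. With so little to go on, the value of compound 2 at 37200 nM is the best starting point, and no shift beyond the scatter is expected. The expected step, a 1.2-fold lower number from compound 2 to compound 3 (0.07 log units; within the scatter), is therefore a small one with no confident direction. For compound 3, the estimated value is 32000 nM, with an expected range from 14000 nM to 50000 nM.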

Compound 3, half-maximal inhibitory concentration: > 50000 nM
Compound 3 gave a limit, no number; the forecaster's own chance of this, stated with the estimate: 25%; middle value at least 1.5-fold (0.19 log units) from the limit.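

Compound 3 sits at a limit and not at a number in this assay. Going by these compounds, the swap of cyclohexylamino for benzylcarbamoyl on a carbonyl carbon therefore yields only a floor, an at least 1.3-fold higher number from compound 2 to compound 3 (0.12 log units; that floor lies within the scatter), so this change brings no sign of stronger inhibition, but no real difference is established either, and the true size of the step stays unknown. What this adds to the earlier comparison is a second group at the far end of the chain that fails to move the read-out clearly into the measurable range, and little can be ranked at this position because the values crowd at the top of that range: the limit of > 50000 nM in this assay, at which 2 of the 3 values shown sit.

On these data alone, it remains open whether a simple amine or a carboxylic acid at the far end of the chain, or a longer chain carrying the same end groups, would give a number well clear of that limit. The compounds shown also leave open how a change on the shared core would act, since every step so far falls on the chain alone.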